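Amide nitrogen substituent change from a limit-bound anchor

The compounds below may be only part of what the source reports. "The series", "measured", "known", "first", "only" and "open" are said of these compounds alone.

Compound 1 `C=CC1=C(C(=O)NCCCCC)C(c2ccc(OC)cc2)OC1` is the anchor of this set. In a functional assay on SW480 cells (Homo sapiens) for cytotoxicity, read by MTT assay, with a stated time of 24 h (a higher number here means a weaker inhibitor, a lower number a stronger inhibitor), compound 1 gives no number, only a limit, > 100000 nM. Compound 3 `C=CC1=C(C(=O)NCCCCC)C(c2ccc(F)cc2)OC1` differs from it by fluoro in place of methoxy on an aromatic carbon; in this assay compound 3 also sits at a limit, > 100000 nM. Compound 2 `C=CC1=C(C(=O)Nc2cccc(C)c2)C(c2ccc(F)cc2)OC1` carries 3-methylphenyl on the amide-type nitrogen; in this assay compound 2 again reports a limit, > 100000 nM. The steps a step that the two limits leave unreadable from compound 1 to compound 3 and a step that the two limits leave unreadable from compound 2 to compound 3 therefore have no readable size, since all three values rest at the limit of > 100000 nM in this assay, at which 3 of the 3 values shown sit.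

Compound 4 `C=CC1=C(C(=O)Nc2ccc(OCC)cc2)C(c2ccc(OC)cc2)OC1` is the next member, differing from compound 1 by 4-ethoxyphenyl in place of pentyl on an amide-type nitrogen. The closest measured change is the aryl-for-pentyl exchange on the amide-type nitrogen, a step that the two limits leave unreadable from compound 2 to compound 3, which is unreadable, so no direction can be drawn from it. Compound 4 is expected to give about 150000 nM in this assay, within 50000 nM to 500000 nM, most likely as another limit. The step that the limit leaves unreadable from compound 1 to compound 4 is accordingly expected to show nothing beyond the scatter.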

Compound 4, half-maximal inhibitory concentration: > 100000 nM
Compound 4 was reported as a limit (the forecaster's own chance of this, stated with the estimate: 80%); the middle value does not contradict the limit.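

Compound 4 gives only a limit in this assay, > 100000 nM, and compound 1 also rests at a limit, so no size can be read for the change between them: the limit of > 100000 nM in this assay, at which 4 of the 4 values shown sit. The compounds shown leave open whether any substituent change on the amide-type nitrogen or aromatic carbon alters cytotoxicity.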